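Diethylamino to pyrrolidin-1-yl on the acrylamide chain

The source may report more compounds than this note shows. Statements on the series, on what has been measured and on what is new or still open speak of the compounds shown alone.

Three analogues sharing one core have been measured in a functional assay on MCF7 cells (Homo sapiens) for antiproliferative activity, read by MTT assay, with a stated time of 72 h; a lower number here means a stronger inhibitor, a higher number a weaker inhibitor. Compound 1 `C/C=C/C(=O)Nc1cc2c(N3CCc4ccccc43)ncnc2cc1OC` gives 4030 nM. Compound 2 `CCC/C=C/C(=O)Nc1cc2c(N3CCc4ccccc43)ncnc2cc1OC` gives 3160 nM. Compound 3 `CCN(CC)C/C=C/C(=O)Nc1cc2c(N3CCc4ccccc43)ncnc2cc1OC` gives 1990 nM, the lowest of the three numbers. The step of a 1.6-fold lower number from compound 2 to compound 3 (0.20 log units; within the scatter) lies within the scatter, and the step of a 2.0-fold lower number from compound 1 to compound 3 (0.31 log units; beyond the scatter) is a modest one beyond it. The step of a 1.3-fold lower number from compound 1 to compound 2 (0.11 log units; within the scatter) is within the scatter.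

Compound 4 `COc1cc2ncnc(N3CCc4ccccc43)c2cc1NC(=O)/C=C/CN1CCCC1` is not yet measured. It differs from compound 3 by pyrrolidin-1-yl in place of diethylamino on a saturated chain carbon bound to a double-bonded chain carbon. Going by the values given here, the measured steps that touch this position are a 2.0-fold lower number from compound 1 to compound 3 (0.31 log units; beyond the scatter) and a 1.6-fold lower number from compound 2 to compound 3 (0.20 log units; within the scatter): they show what putting diethylamino on the saturated chain carbon does against hydrogen or ethyl, but no measured pair swaps one amine for another. The step from diethylamino to pyrrolidin-1-yl is therefore expected to be small, a 1.1-fold lower number from compound 3 to compound 4 (0.04 log units; within the scatter), with no change beyond the scatter in either direction. For compound 4 the expected value in this assay is 1800 nM, in a range of 900 nM to 3600 nM.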

Compound 4, half-maximal inhibitory concentration: 1510 nM
For compound 4 the middle estimate is 1.2-fold (0.08 log units) above the measured one; the range from low to high includes it.
By their numbers in this assay, from the lowest: compounds 4, 3, 2 and 1 (each within the scatter of the next, the first and the last beyond it).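

Working notes on the amine at the saturated chain carbon bound to a double-bonded chain carbon: in this assay, this is the first measured pair that swaps one amine for another, and replacing diethylamino with pyrrolidin-1-yl, which ties the open chains into a ring without changing the heavy-atom count, gives only a small shift within the scatter (a 1.3-fold lower number from compound 3 to compound 4 (0.12 log units; within the scatter)). Compound 4 also extends the earlier picture, as the step from the ethyl end of the chain is beyond the scatter (a 2.1-fold lower number from compound 2 to compound 4 (0.32 log units; beyond the scatter)), whereas the corresponding step to diethylamino was not, and the step from the hydrogen analogue is the largest in the series, though still modest (a 2.7-fold lower number from compound 1 to compound 4 (0.43 log units; beyond the scatter)). Nothing available explains these shifts or connects them to any measured property of the groups.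

From the compounds shown here alone, it remains open whether other amines at this position, such as dimethylamino, piperidin-1-yl or morpholin-4-yl, would separate from compound 3 and compound 4 by more than the scatter. Going by these compounds, it is also open whether the nitrogen matters at all, a question that cyclopentyl, the all-carbon counterpart of pyrrolidin-1-yl, could address at the same carbon.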